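Aryl substituent change: dimethylamino to chloro

The compounds below may be only part of what the source reports. "The series", "measured", "known", "first", "only" and "open" are said of these compounds alone.

Going by the values given here, compound 2 `CC1=CC[C@H](C(C)(C)NC(=S)N/N=C/c2ccc(N(C)C)cc2)CC1` gives 45100 nM in a functional assay on UACC-62 cells (Homo sapiens) for inhibition, read by sulforhodamine B assay, with a stated time of 48 h (a lower number here means a stronger inhibitor of growth, a higher number a weaker inhibitor of growth), the highest of the two numbers measured so far; compound 1 `COc1ccc(/C=N/NC(=S)NC(C)(C)[C@H]2CC=C(C)CC2)cc1` gives 13300 nM. Compound 3 `CC1=CC[C@H](C(C)(C)NC(=S)N/N=C/c2ccc(Cl)cc2)CC1` carries chloro in place of dimethylamino on an aromatic carbon. Among the compounds with values here, the only measured step bearing on this position is a 3.4-fold higher number from compound 1 to compound 2 (0.53 log units; beyond the scatter), where the dimethylamino raised the number. Removing the dimethylamino again, now for chloro, is expected to lower the number in this assay by roughly that size. Chloro has no measured precedent in the series, and the range is wide. Compound 3 is estimated at 15000 nM (range 5000 nM to 45000 nM), an expected step of a 3.0-fold lower number from compound 2 to compound 3 (0.48 log units; beyond the scatter).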

Compound 3, concentration for 50% growth inhibition: 11200 nM
Compound 3: the middle estimate sits 1.3-fold (0.13 log units) above what was measured, and the stated range covers the measured number.
By their numbers in this assay, from the lowest: compounds 3 and 1 (each within the scatter of the next); then compound 2.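

In this assay chloro in place of dimethylamino gives a 4.0-fold lower number from compound 2 to compound 3 (0.60 log units; beyond the scatter) and chloro in place of methoxy gives a 1.2-fold lower number from compound 1 to compound 3 (0.07 log units; within the scatter) as its reading. At this position chloro and methoxy therefore cannot be told apart, while dimethylamino stands alone with the highest number among the three compounds. The data available give no reason for this difference.

Open, as far as these compounds go, is whether a primary amine or a carboxylic acid at this position would read with compound 2 or with compounds 1 and 3. Also open, from the compounds shown here alone, is whether a fluoro or a bromo would read with chloro.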